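This account rests on a few compounds, and the source may have more. Where it says the series, first, only, none or still open, it means among the compounds named here.

Going by the values given here, in a functional assay (aorta) with Rattus norvegicus as the target (on this read-out higher numbers stand for weaker inhibition and lower numbers for stronger inhibition), compound 2 `CSc1cccc(N/C(=N/[C@@H]2c3cc(C#N)ccc3OC(C)(C)[C@H]2O)NC#N)c1` gives 1400 nM, the only true number so far. Compound 1 `CC1(C)Oc2ccc(C#N)cc2[C@@H](/N=C(\NC#N)Nc2ccc(C(=O)O)cc2)[C@@H]1O` gives > 100000 nM, which is a limit of the assay and not a number. Compound 3 `CSc1ccc(N/C(=N/[C@@H]2c3cc(C#N)ccc3OC(C)(C)[C@H]2O)NC#N)cc1` has 4-(methylsulfanyl)phenyl in place of 3-(methylsulfanyl)phenyl on an amine nitrogen. Among the compounds with values here, the only measured step, an at least 71-fold lower number from compound 1 to compound 2 (1.85 log units; beyond the scatter), is large, but it exchanged a 4-carboxyphenyl group, so it bears only loosely on this change. The expected result is a 1.4-fold higher number from compound 2 to compound 3 (0.15 log units; within the scatter), with no shift beyond the scatter expected in this assay. For compound 3 the estimated value is 2000 nM, with an expected range of 500 nM to 10000 nM.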

Compound 3, half-maximal inhibitory concentration: 6300 nM
The estimate for compound 3 lay 3.2-fold (0.50 log units) below the measured number; the range from low to high includes it.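

Moving the methylsulfanyl group matters: in this assay there is a 4.5-fold higher number from compound 2 to compound 3 (0.65 log units; beyond the scatter), so 3-(methylsulfanyl)phenyl and 4-(methylsulfanyl)phenyl are not interchangeable on this amine nitrogen. Even so, there is an at least 15-fold lower number from compound 1 to compound 3 (1.20 log units; beyond the scatter), so 4-(methylsulfanyl)phenyl still gives a far lower number than 4-carboxyphenyl in the same place. That second step has no exact size, as compound 1 stands at a limit of the assay: the limit of > 100000 nM in this assay, at which 1 of the 3 values shown sits.

Still open, from the compounds shown here alone, is whether an ethylsulfanyl group or an amine on the phenyl ring would show the same dependence on where it sits.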